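Opening the Ring on the Nitrogen of Compound 3

The source may hold more compounds than are shown below. What is called first, only, known or untested is meant among the compounds shown, and "the series" means these compounds.

Of the compounds shown here, three built on one shared core have been measured in an assay on HEK293 cells for positive allosteric modulation of metabotropic glutamate receptor 2 (Rattus norvegicus), read by thallium flux; on this read-out higher numbers stand for an effect only at larger amounts of compound and lower numbers for an effect already at smaller amounts. In this assay compound 1 `O=C(O)c1cc(-c2cccc(COc3ccc4c(=O)n(CC5CC5)sc4c3)c2)ccc1Cl` gives 2480 nM. Compound 2 `COc1ccc(C(=O)O)cc1-c1cccc(COc2ccc3c(c2)CN(C2CCCC2)C3=O)c1` gives 80 nM. Compound 3 `O=C(O)c1cc(-c2cccc(COc3ccc4c(=O)n(C5CCC5)sc4c3)c2)ccc1Cl` gives 580 nM, so compound 3 stands second highest of the three numbers, with compound 1 nearest to it and compound 2 furthest from it.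

Compound 4 `CC(C)Cn1sc2cc(OCc3cccc(-c4ccc(Cl)c(C(=O)O)c4)c3)ccc2c1=O` differs from compound 3 in one place: isobutyl in place of cyclobutyl on an aromatic nitrogen. Among the measured compounds shown here, the only measured step at this nitrogen is a 4.3-fold lower number from compound 1 to compound 3 (0.63 log units; beyond the scatter), in which the group that is a ring itself gave a lower number than the group carrying a ring through one chain carbon. Isobutyl has no ring, and in that respect stands closer to cyclopropylmethyl than to cyclobutyl, so the change is expected to carry the number upward, partly back toward compound 1, by a modest step beyond the scatter, a 2.6-fold higher number from compound 3 to compound 4 (0.41 log units; beyond the scatter). For compound 4 in this assay the estimate is 1500 nM, within a range from 500 nM to 4500 nM.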

Compound 4, half-maximal effective concentration: 470 nM
Compound 4: middle estimate off by 3.2-fold (0.50 log units), on the high side; the whole stated range lies above it.
By their numbers in this assay, from the lowest: compound 2; then compounds 4 and 3 (each within the scatter of the next); then compound 1.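

Opening the ring on the aromatic nitrogen leaves the number in this assay unchanged within the scatter, with a 1.2-fold lower number from compound 3 to compound 4 (0.09 log units; within the scatter), so the closed ring of cyclobutyl is not what separates compound 3 from compound 1. The clearer contrast lies on the saturated chain carbon bound to the aromatic nitrogen, where isopropyl in place of cyclopropyl gives a 5.3-fold lower number from compound 1 to compound 4 (0.72 log units; beyond the scatter); among these three compounds, it is the cyclopropylmethyl group of compound 1 that stands apart. Nothing available here accounts for why that group differs from the other two.

As far as these compounds go, whether a longer chain, such as pentyl, would keep the number in this range remains open. So does the outcome with an amine or a methoxyethyl group on this nitrogen, and with cyclobutylmethyl, which would show whether the result for cyclopropylmethyl extends to a larger ring on the same chain carbon.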